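Fluoro for methyl on the tolyl arm of compound 2

A few compounds are considered here, and "the series" means these few. Any claim that something is new, unique, unknown or untested is made for them only; others in the source may bear on it.

Measured so far:
Compound 1, `Cc1ccc(C2=NN(C3=NC(=O)CS3)C(c3ccc4ccccc4c3)C2)cc1`: 12700 nM
Compound 2, `Cc1ccc(C2=NN(C3=NC(c4ccccc4)CS3)C(c3ccc4ccccc4c3)C2)cc1`: 14700 nM
Compound 3, `Cc1ccc(C2=NN(C3=NC(=O)CS3)C(c3cccc4ccccc34)C2)cc1`: 8660 nM

In a functional assay on HepG2 cells (Homo sapiens) for inhibition, read by CCK-8 assay, with a stated time of 48 h (a higher number here means a weaker inhibitor, a lower number a stronger inhibitor), the three numbers sit close together. Compound 2 has the nominally top number, but its gaps to compound 1 and to compound 3 are both within the scatter, so none of the three can be ranked against another. Among the compounds with values here, the only measured step, a 1.2-fold higher number from compound 1 to compound 2 (0.06 log units; within the scatter), exchanges the group on the ring amine nitrogen and shifts nothing beyond the scatter.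

Compound 4, `Fc1ccc(C2=NN(C3=NC(c4ccccc4)CS3)C(c3ccc4ccccc4c3)C2)cc1`, differs from compound 2 by fluoro in place of methyl on an aromatic carbon, so that the 4-methylphenyl becomes 4-fluorophenyl. Within the data shown here, no measured pair shows this change, and the one measured step concerns another part of the core, so no basis exists for predicting a shift beyond the scatter. Compound 4 is therefore expected to give about 15000 nM, with a range from 5000 nM to 45000 nM, meaning an expected step of a 1.0-fold higher number from compound 2 to compound 4 (0.01 log units; within the scatter).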

Compound 4, half-maximal inhibitory concentration: 26500 nM
For compound 4 the middle estimate is 1.8-fold (0.25 log units) below the measured one; the range from low to high includes it.
By their numbers in this assay, from the lowest: compounds 3, 1, 2 and 4 (each within the scatter of the next, the first and the last beyond it).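

In this assay, within the data shown here, fluoro in place of methyl on the aromatic ring gives a 1.8-fold higher number from compound 2 to compound 4 (0.26 log units; within the scatter), the first measured step at the 4-methylphenyl arm, as the earlier step concerned the group on the ring amine nitrogen. At this position, then, this exchange of one heavy atom for another stays within the scatter. Nothing at hand explains the size of this step. From the compounds shown here alone, whether a larger group here, such as methoxy, a dimethylamine or a carboxylic acid, would go beyond the scatter remains open. So does whether the same exchange would give a similar step on the core of compound 1.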